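Trifluoromethoxy in place of chloro: expectation for compound 3

The compounds below may be only part of what the source reports. "The series", "measured", "known", "first", "only" and "open" are said of these compounds alone.

Within the data shown here, in a functional assay on MDA-MB-231 cells (Homo sapiens) for antiproliferative activity, read by MTT assay, with a stated time of 72 h (on this read-out lower numbers stand for stronger inhibition and higher numbers for weaker inhibition), compound 1 `O=C(CCc1cccc2c1B(O)OC2)Nc1cccc(-c2cccc(F)c2)c1` gives 570 nM and compound 2 `O=C(CCc1cccc2c1B(O)OC2)Nc1cccc(-c2cccc(Cl)c2)c1` gives 250 nM, so compound 2 holds the lowest of the two numbers so far. The next compound is compound 3 `O=C(CCc1cccc2c1B(O)OC2)Nc1cccc(-c2cccc(OC(F)(F)F)c2)c1`, which carries trifluoromethoxy in place of chloro on an aromatic carbon, meta to a large group: trifluoromethoxy in place of chloro on an aromatic carbon.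

Among the measured compounds shown here, only one measured step bears on this change: a 2.3-fold lower number from compound 1 to compound 2 (0.36 log units; beyond the scatter), a modest step beyond the scatter, with chloro in place of fluoro on an aromatic carbon. For the measured compounds named here, that step compares two halogens only, and no compound with trifluoromethoxy has been measured, so it offers little guidance on direction. A step no larger than that one is the working expectation in this assay, quite possibly none beyond the scatter. The estimated step is a 1.2-fold higher number from compound 2 to compound 3 (0.08 log units; within the scatter), a slightly higher number that is expected to stay within the scatter. For compound 3 the estimated value is 300 nM, with an expected range of 120 nM to 750 nM.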

Compound 3, half-maximal inhibitory concentration: 460 nM
For compound 3 the middle estimate is 1.5-fold (0.19 log units) below the measured one, and the stated range covers the measured number.
By their numbers in this assay, from the lowest: compounds 2, 3 and 1 (each within the scatter of the next, the first and the last beyond it).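

In this assay, this aromatic carbon, meta to a large group, takes trifluoromethoxy, with 5 heavy atoms where chloro has 1 heavy atom, and the result stays within the scatter of chloro (a 1.8-fold higher number from compound 2 to compound 3 (0.26 log units; within the scatter)). Against fluoro the picture is the same (a 1.2-fold lower number from compound 1 to compound 3 (0.09 log units; within the scatter)), so compound 3 cannot be separated from either halogen compound, although the two halogen compounds are separated from each other (a 2.3-fold lower number from compound 1 to compound 2 (0.36 log units; beyond the scatter)); the series therefore gives a clear order only for chloro and fluoro, and trifluoromethoxy has no firm place in it. No measurement is available that would explain these numbers.

Still open, going by these compounds, is whether a group of another kind on this carbon, such as an amine, a carboxylic acid, a nitrile or a longer alkoxy chain, would stay in this same range or leave it. Also open, on these data alone, is whether the plain hydrogen compound would sit with these three, which would show whether any substituent here matters at all in this assay.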